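The source may report more compounds than this note shows. Statements on the series, on what has been measured and on what is new or still open speak of the compounds shown alone.

Measured so far:
- compound 1, `Cc1cn([C@H]2C[C@H](SSc3ccccc3[N+](=O)[O-])[C@@H](CO)O2)c(=O)[nH]c1=O`: < 0.0834 h
- compound 2, `CCCCCCSS[C@H]1C[C@H](n2cc(C)c(=O)[nH]c2=O)O[C@@H]1CO`: < 0.0834 h

Both readings in a physicochemical assay for pharmacokinetics, at pH 7.2 (a higher number here means that the compound lasts longer, a lower number that the compound disappears faster), are limits of the assay, not numbers. For compound 1 the reading < 0.0834 h is such a limit. For compound 2 the reading < 0.0834 h is likewise a limit. Within the data shown here, the one change between them, a step that the two limits leave unreadable from compound 1 to compound 2, therefore cannot be sized: both values sit on (the limit of < 0.0834 h in this assay, at which 2 of the 2 values shown sit). Among the measured compounds shown here, compound 2 thus stands at the lower edge of what this assay reports, and no measured compound of the pair stands anywhere else.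

The next compound, compound 3, `Cc1cn([C@H]2C[C@H](SSCCO)[C@@H](CO)O2)c(=O)[nH]c1=O`, differs from compound 2 by hydroxy in place of butyl on a saturated chain carbon, two bonds along the chain from a sulfur. For the measured compounds named here, the only measured step, from compound 1 to compound 2, concerns the other substituent on the disulfide and is unreadable, so it gives no size for the present change. With nothing measured pointing to a longer half-life, compound 3 is expected to remain at or near the limit; the estimated step is a step that the limit leaves unreadable from compound 2 to compound 3. Compound 3 is estimated at 0.05 h, within 0.01 h to 0.3 h.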

Compound 3, half-life: < 0.0834 h
Compound 3 ended at the assay's limit (the forecaster's own chance of this, stated with the estimate: 70%); the middle value does not contradict the limit.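

No step among compound 1, compound 2 and compound 3 can be read, since all three readings in this assay are limits, not numbers: the limit of < 0.0834 h in this assay, at which 3 of the 3 values shown sit.

The compounds shown leave open how long any of the three actually lasts, and whether changing the group on the sulfur alters the half-life at all.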